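Enlarging the Amide Substituent on a Shared Inhibitor Core

This account rests on a few compounds, and the source may have more. Where it says the series, first, only, none or still open, it means among the compounds named here.

Measured so far:
Compound 1 `Cn1ccc2ccc(-c3cc(Nc4ccccc4S(N)(=O)=O)cc4nccnc34)cc21` gives 265 nM in an assay for inhibition of 6-phosphofructo-2-kinase/fructose-2,6-bisphosphatase 3 (Homo sapiens), read by ADP-Glo, with a stated time of 2 h; a higher number here means a weaker inhibitor, a lower number a stronger inhibitor.
Compound 2 `CN(Cc1cncnc1)S(=O)(=O)c1ccccc1Nc1cc(-c2ccc3ccn(C)c3c2)c2nccnc2c1` gives 62 nM in this assay.
Compound 3 `CN(C)C(=O)c1ccncc1Nc1cc(-c2ccc3ccn(C)c3c2)c2nccnc2c1` gives 499 nM in this assay.

All three compounds share the same core and differ only in the group attached to it. Compound 3 carries the highest of the three numbers in this assay. Its gap to compound 1 lies within the scatter of repeated measurements, so those two cannot be ordered against each other, whereas compound 2 sits clearly lower than both.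

Compound 4 `CC(=O)N1CCC(NC(=O)c2ccncc2Nc2cc(-c3ccc4ccn(C)c4c3)c3nccnc3c2)CC1` has not been measured. It differs from compound 3 in one place: (1-acetylpiperidin-4-yl)amino in place of dimethylamino on a carbonyl carbon. Within the data shown here, the only step measured between two compounds is a 4.3-fold lower number from compound 1 to compound 2 (0.63 log units; beyond the scatter); there a small group on a sulfonyl sulfur was replaced by a much larger one, and the number fell. That change sits at a different place from the present one, on a sulfonyl sulfur rather than a carbonyl carbon, so it is only a loose guide. Taking it as the nearest precedent, a modest lowering is expected, a 1.7-fold lower number from compound 3 to compound 4 (0.22 log units; within the scatter). Compound 4 is therefore estimated at 300 nM, with a likely range from 100 nM to 900 nM.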

Compound 4, half-maximal inhibitory concentration: 18 nM
Compound 4: the middle estimate sits 17-fold (1.22 log units) above what was measured; measured number outside the range, below it.
By their numbers in this assay, from the lowest: compound 4; then compound 2; then compounds 1 and 3 (each within the scatter of the next).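

Replacing dimethylamino with (1-acetylpiperidin-4-yl)amino on the carbonyl carbon gives a 28-fold lower number from compound 3 to compound 4 (1.44 log units; beyond the scatter) in this assay, which shows that this place accepts a far larger substituent and that the number can move strongly there. The entering group brings in a six-membered non-aromatic ring, a hydrogen-bond donor, a hydrogen-bond acceptor and several more heavy atoms all at once, so this single step cannot show which of these features matters. No measurement accompanies the step that would explain the fall in the number, and its reason stays unknown.

The compounds shown leave open which part of the new group goes with the lower number: the same ring with its acetyl group removed, leaving a free amine, or a simple methylamino group on the carbonyl carbon would begin to separate these parts. It also remains open whether (1-acetylpiperidin-4-yl)amino would behave in the same way on the sulfonyl sulfur of compound 1, where methyl((pyrimidin-5-yl)methyl)amino is the only larger group shown.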